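Chloro position on the benzamide of the cyclohexyl-diamine series

A few compounds are considered here, and "the series" means these few. Any claim that something is new, unique, unknown or untested is made for them only; others in the source may bear on it.

Three compounds of the series have numbers in a functional assay on HEK293 cells for antagonist activity at melanin-concentrating hormone receptor 1 (Homo sapiens), read by FLIPR and calcium flux; on this read-out lower numbers stand for stronger inhibition and higher numbers for weaker inhibition. Compound 1 `CCN(C)c1nc(N[C@H]2CC[C@@H](NC(=O)c3ccc(F)c(F)c3)CC2)ncc1C` gives 46 nM. Compound 2 `Cc1cnc(N[C@H]2CC[C@@H](CNC(=O)c3cc(C(F)(F)F)cc(C(F)(F)F)c3)CC2)nc1N` gives 600 nM. Compound 3 `Cc1cc(N(C)C)nc(N[C@H]2CC[C@@H](NC(=O)c3ccc(Cl)cc3)CC2)n1` gives 16 nM, the lowest of the three numbers: compound 1 lies beyond the scatter above it, and compound 2 lies far beyond the scatter above it. Compound 3 is thus the most potent of the measured compounds on this read-out.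

Compound 4 `Cc1cc(N(C)C)nc(N[C@H]2CC[C@@H](NC(=O)c3cccc(Cl)c3)CC2)n1` keeps the whole of compound 3 except for one change: 3-chlorophenyl in place of 4-chlorophenyl on a carbonyl carbon. For the measured compounds named here, no measured pair in the set shows this same change, so its effect is not known from the numbers at hand. The expectation is a small step from compound 3 to compound 4, a 2.2-fold higher number from compound 3 to compound 4 (0.34 log units; beyond the scatter), most likely toward a somewhat higher number, and not clearly beyond the scatter. Compound 4 is therefore estimated at 35 nM in this assay, within a range from 12 nM to 110 nM.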

Compound 4, half-maximal inhibitory concentration: 6.5 nM
Beside the measured number, compound 4's estimate is 5.4-fold (0.73 log units) above it; measured number outside the range, below it.
By their numbers in this assay, from the lowest: compound 4; then compound 3; then compound 1; then compound 2.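

In this assay, moving the chlorine from 4-chlorophenyl to 3-chlorophenyl on the carbonyl carbon gives a 2.5-fold lower number from compound 3 to compound 4 (0.39 log units; beyond the scatter), so this position responds to where the chlorine sits, even with the same atoms on both sides of the change. For the compounds shown here, this is the first step that can be read at a single place, since compound 1 and compound 2 each differ from compound 3 in more than one place. Nothing at hand says why 3-chlorophenyl gives the lower number.

Open, going by these compounds, is whether a bromine, a nitrile or a methoxy group in place of the chlorine would keep or lose this step. Also open, on these data alone, is whether the same chlorine move carries over to the core of compound 1.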